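This account rests on a few compounds, and the source may have more. Where it says the series, first, only, none or still open, it means among the compounds named here.

Compounds measured in an assay on a protein complex for inhibition of CDK8/Cyclin C (Homo sapiens), with a stated time of 1 h; on this read-out higher numbers stand for weaker inhibition and lower numbers for stronger inhibition:
- compound 1 `NNC(=O)CCc1ccncc1-c1ccc2ccccc2c1`: 7.7 nM
- compound 2 `O=C(CCc1ccncc1-c1ccc2ccccc2c1)N1CCOCC1`: 45.5 nM
- compound 3 `NC(=O)/C=C/c1ccncc1Br`: 2420 nM

Compound 2 stands second highest of the three numbers in this assay; its nearest neighbour is compound 1, and the step of a 5.9-fold higher number from compound 1 to compound 2 (0.77 log units; beyond the scatter) lies beyond the scatter. Compound 3, on a different core, gives the highest number.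

Compound 4 `O=C(O)CCc1ccncc1-c1ccc2ccccc2c1` differs from compound 2 by hydroxy in place of morpholin-4-yl on a carbonyl carbon. Going by the values given here, only one measured step bears on changes at this carbonyl carbon, a 5.9-fold higher number from compound 1 to compound 2 (0.77 log units; beyond the scatter), a modest change. The move from compound 2 to compound 4 replaces the group that was itself introduced in that step, and no acid has been measured in the series. A further modest rise is expected: a 4.0-fold higher number from compound 2 to compound 4 (0.60 log units; beyond the scatter). Compound 4 is estimated at 180 nM, with a range of 45 nM to 700 nM.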

Compound 4, half-maximal inhibitory concentration: 50.5 nM
Compound 4: the middle estimate sits 3.6-fold (0.55 log units) above what was measured, within the range that was stated.
By their numbers in this assay, from the lowest: compound 1; then compounds 2 and 4 (each within the scatter of the next); then compound 3.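

In this assay, morpholin-4-yl and hydroxy on a carbonyl carbon give numbers that stand level (a 1.1-fold higher number from compound 2 to compound 4 (0.05 log units; within the scatter)), so the ring of morpholin-4-yl makes no readable difference between this pair. Aminoamino alone stands apart among the three groups, as compound 1 also separates from the acid compound 4 (a 6.6-fold higher number from compound 1 to compound 4 (0.82 log units; beyond the scatter)). No measurement at hand accounts for this.

Still open, as far as these compounds go, is whether a primary amide, a methyl ester or a simple amine on this carbonyl carbon would read with compound 1 or with compounds 2 and 4. A longer chain to the carbonyl is equally untested here.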